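Two limits and one isopropoxy swap

A few compounds are considered here, and "the series" means these few. Any claim that something is new, unique, unknown or untested is made for them only; others in the source may bear on it.

Measured in an ADME assay on Raji cells (Homo sapiens) for cytotoxicity, read by luminescence, with a stated time of 72 h; on this read-out lower numbers stand for an effect already at smaller amounts and higher numbers for an effect only at larger amounts of compound
Compound 1 `CCOC(=O)c1c(-c2cc(F)cc(OC)c2)[nH]c2cc(OC)ccc2c1=O` gives > 21500 nM
Compound 2 `C=Cc1cccc(-c2[nH]c3cc(OC)ccc3c(=O)c2C(=O)OCC)c1` gives > 21500 nM

Neither entry is an exact number. Compound 2 stands at > 21500 nM, which is a limit of the assay. Compound 1 shares this position, and the picture so far is the limit of > 21500 nM in this assay, at which 2 of the 2 values shown sit.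

Compound 3 `CCOC(=O)c1c(-c2cccc(OC(C)C)c2)[nH]c2cc(OC)ccc2c1=O` keeps the core and the ester of compound 2 but carries isopropoxy in place of vinyl on an aromatic carbon. Among the measured compounds shown here, the only measured step that bears on this change is a step that the two limits leave unreadable from compound 1 to compound 2. It replaced 3-fluoro-5-methoxyphenyl with 3-vinylphenyl at the same place, so it concerns the same aromatic substituent, but it gives no size to carry forward. No direction can therefore be read from the data, and the most likely outcome in this assay is another limit rather than a number. The expected change is a step that the limit leaves unreadable from compound 2 to compound 3, an estimate with no clear direction. Compound 3 is expected at about 25000 nM, with an estimated range from 9000 nM to 60000 nM.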

Compound 3, half-maximal effective concentration: > 21500 nM
Compound 3: no number, only a limit; the forecaster's own chance of this, stated with the estimate: 80%; the middle value lies beyond the limit too.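

In this assay compound 3 gives > 21500 nM, which is a limit and not a number. No step from compound 2 to compound 3 can therefore be read, and the values share one position: the limit of > 21500 nM in this assay, at which 3 of the 3 values shown sit.

On these data alone, whether compound 1, compound 2 and compound 3 differ at all in this assay, and whether any aromatic substituent would give an exact number there, stays open.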